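Compound 4 follows compound 3 with one more methyl

A few compounds are considered here, and "the series" means these few. Any claim that something is new, unique, unknown or untested is made for them only; others in the source may bear on it.

Measured compounds:
compound 1, `CCCCN(CC)c1cc(C)nc2c1NC(=O)CN2c1ccc(C)cc1Cl`, 4.4 nM
compound 2, `CCCCN(CC)c1cc(C)nc2c1NC(=O)CN2c1ccc(C)cc1C`, 3.9 nM
compound 3, `CCCCN(CC)c1cc(C)nc2c1NC(=O)CN2c1ccc(C(C)C)cc1Br`, 2.4 nM

Compound 3 gives the lowest of the three numbers in an assay on HEK-293T cells for displacement of a labelled ligand from corticotropin-releasing factor receptor 1 (Homo sapiens), read by scintillation counting, with a stated time of 2 h (a higher number here means a weaker inhibitor, a lower number a stronger inhibitor), but its distance to compound 2 and to compound 1 is within the scatter, so the three compounds cannot be ordered against each other. Compound 4, `CCCCN(CC)c1cc(C)nc2c1NC(=O)CN2c1ccc(C(C)(C)C)cc1Br`, differs from compound 3 by methyl in place of hydrogen on a saturated chain carbon bound to an aromatic carbon and two saturated chain carbons; cut one bond further out, the same difference reads isopropyl to tert-butyl. Among the compounds with values here, no measured step touches this part of the molecule. Within the data shown here, the one measured step, a 1.1-fold lower number from compound 1 to compound 2 (0.05 log units; within the scatter), concerns a change on the aromatic ring elsewhere and lies within the scatter, so it bears only indirectly on the question and suggests that small changes in this region of the shared core have so far left the number in this assay about where it was. The step expected for compound 4 is therefore a 1.3-fold higher number from compound 3 to compound 4 (0.10 log units; within the scatter), a change not beyond the scatter in either direction. Compound 4 is expected to give about 3 nM in this assay, with a range from 1.2 nM to 8 nM.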

Compound 4, inhibition constant: 4.2 nM
Estimate against measurement, compound 4: 1.4-fold (0.15 log units) below; the range from low to high includes it.
By their numbers in this assay, from the lowest: compounds 3, 2, 4 and 1 (each within the scatter of the next).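

Within the data shown here, this is the first measured change at this position: in this assay isopropyl to tert-butyl gives a 1.8-fold higher number from compound 3 to compound 4 (0.24 log units; within the scatter) and so cannot be read as a real loss. Within the compounds shown, then, methyl in place of hydrogen on this saturated chain carbon leaves the number inside the scatter, and a tert-butyl group here is compatible with a value in the same low range as the other three compounds. Nothing shown gives a reason for this result.

As far as these compounds go, it remains open whether a different group at this place, such as a carboxylic acid, an amine or a longer chain, would move the number beyond the scatter. From the compounds shown here alone, it is also open whether tert-butyl would give the same result alongside the chloro of compound 1 or the methyl of compound 2 in place of bromo.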